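From 4-Chlorobenzyl to 4-Methylbenzyl: An Expected Small Step

This account rests on a few compounds, and the source may have more. Where it says the series, first, only, none or still open, it means among the compounds named here.

In a functional assay on KYSE-450 cells (Homo sapiens) for inhibition, read by CCK-8 assay, with a stated time of 48 h (a lower number here means a stronger inhibitor, a higher number a weaker inhibitor), compound 1 (`COc1ccc(CN(C(=O)CSC(=S)N2CCCc3cc(OC)ccc32)c2cc(OC)c(OC)c(OC)c2)cc1`) gives 5530 nM, compound 2 (`CCN1CCN(CC(=O)N(Cc2ccc(OC)cc2)c2cc(OC)c(OC)c(OC)c2)CC1`) gives 16100 nM, and compound 3 (`COc1cc(N(Cc2ccc(Cl)cc2)C(=O)CSC(=S)N2CCN(C(=O)OC(C)(C)C)CC2)cc(OC)c1OC`) gives 11900 nM. Compound 3 thus lies within the scatter of compound 2, while compound 1 shows a lower number, beyond the scatter. Compound 4 (`COc1cc(N(Cc2ccc(C)cc2)C(=O)CSC(=S)N2CCN(C(=O)OC(C)(C)C)CC2)cc(OC)c1OC`) differs from compound 3 as follows: methyl in place of chloro on an aromatic carbon. This places methyl in place of chloro on an aromatic carbon, para to a large group. For the measured compounds named here, no measured pair shows this change, so the expectation is for no shift beyond the scatter. The estimated step, a 1.1-fold lower number from compound 3 to compound 4 (0.03 log units; within the scatter), stays small. For compound 4 the estimated value is 11000 nM, with an expected range of 5000 nM to 23000 nM.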

Compound 4, half-maximal inhibitory concentration: > 20000 nM
Compound 4: only a limit was reported; the forecaster's own chance of this, stated with the estimate: 3%; at least 1.8-fold (0.25 log units) between middle value and limit.
By their numbers in this assay, from the lowest: compound 1; then compounds 3 and 2 (each within the scatter of the next). At a limit, above all of these: compound 4.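

In this assay, methyl in place of chloro on this aromatic carbon, para to a large group, gives an at least 1.6-fold higher number from compound 3 to compound 4 (0.22 log units; that floor lies within the scatter). For the compounds shown here, compound 4 reads > 20000 nM, which is a limit and not a number: the limit of > 20000 nM in this assay, at which 1 of the 4 values shown sits. The earlier compounds offered no pair across this change, and this pair gives only a floor, so the true size of the step cannot be read.

The compounds shown leave open how a fluoro, a nitrile or an amine on this carbon would read. They also leave open whether the same change would behave alike on the core of compound 1.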